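This account rests on a few compounds, and the source may have more. Where it says the series, first, only, none or still open, it means among the compounds named here.

Compound 3 `CCC(NC(=O)CNC(=O)c1ccc(F)cc1)c1ccccc1` carries an ethyl group on the saturated chain carbon bound to an amide-type nitrogen and an aromatic carbon. In an assay for inhibition of sodium- and chloride-dependent glycine transporter 1 (Homo sapiens) (on this read-out higher numbers stand for an effect only at larger amounts of compound and lower numbers for an effect already at smaller amounts), compound 3 gives 4100 nM, the highest of the two single numbers recorded; its nearest neighbour is compound 2 `O=C(CNC(=O)c1ccc(F)cc1)NC(c1ccccc1)c1ccccc1`, which in this assay gives 110 nM. Compound 1 `O=C(CNC(=O)c1ccc(F)cc1)NC(c1ccccc1)c1ccc(Cl)cc1`, which bears a chlorophenyl group at the same carbon, gives 88 nM; 88 nM (2 entries) in this assay, and its two entries sit close to the number for compound 2.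

Compound 4 `O=C(CNC(=O)c1ccc(F)cc1)NC(c1ccccc1)c1ccncc1` differs from compound 3 by pyridin-4-yl in place of ethyl on a saturated chain carbon bound to an amide-type nitrogen and an aromatic carbon. Among the compounds with values here, the one measured step that bears directly on this change is a 37-fold higher number from compound 2 to compound 3 (1.57 log units; beyond the scatter), where an aromatic ring was replaced by ethyl. The present change runs the other way, bringing back a six-membered aromatic ring, now with one ring nitrogen. The step is therefore expected to be large and downward, roughly reversing the earlier one: a 21-fold lower number from compound 3 to compound 4 (1.31 log units; beyond the scatter). Compound 4 is accordingly estimated to reach 200 nM in this assay, with a range from 60 nM to 700 nM.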

Compound 4, half-maximal effective concentration: 730 nM
The estimate for compound 4 lay 3.7-fold (0.56 log units) below the measured number; measured number outside the range, above it.
By their numbers in this assay, from the lowest: compound 2; then compound 4; then compound 3.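

At the saturated chain carbon bound to an amide-type nitrogen and an aromatic carbon, restoring a six-membered aromatic ring recovers only part of what the change to ethyl lost: in this assay the result is a 5.6-fold lower number from compound 3 to compound 4 (0.75 log units; beyond the scatter), yet also a 6.6-fold higher number from compound 2 to compound 4 (0.82 log units; beyond the scatter). The earlier compounds shown here had set phenyl against ethyl and compared phenyl with chlorophenyl, whereas this pair shows that an aromatic ring at this carbon is not enough in itself to match phenyl, since pyridin-4-yl, with its one ring nitrogen, falls between phenyl and ethyl. Nothing available here accounts for this difference between the two rings.

As far as these compounds go, it remains open whether pyridin-3-yl or pyridin-2-yl at this carbon would follow pyridin-4-yl or stay closer to phenyl. Whether a saturated ring such as cyclohexyl could take the place of phenyl also remains unanswered.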